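Swapping a Methyl for Chlorine on the Benzyl Arm

A few compounds are considered here, and "the series" means these few. Any claim that something is new, unique, unknown or untested is made for them only; others in the source may bear on it.

Among the compounds with values here, in an assay on isolated protein for inhibition of kallikrein-7 (Homo sapiens), read by fluorescence, with stated times of 10 min and 30 min (on this read-out lower numbers stand for stronger inhibition and higher numbers for weaker inhibition), compound 2 `Cc1cccc(F)c1CC1CN/C(=N\N(C)C)CN(CC(=O)Nc2cccc(-c3cnn(C)c3)c2)C1=O` gives 2300 nM, the only number it has there, with one further entry that gave no single number. Compound 1 `CN(C)/N=C1/CN(CC(=O)Nc2cccc(-c3cnn(C)c3)c2)C(=O)C(Cc2c(Cl)cccc2Cl)CN1` gives 790 nM; > 30000 nM; 380 nM (3 entries) in this assay, several entries that spread widely. Compound 3 `CN(C)/N=C1/CN(CC(=O)Nc2cccc(-c3cnn(C)c3)c2)C(=O)C(Cc2c(F)cccc2Cl)CN1` differs from compound 2 by chloro in place of methyl on an aromatic carbon. Within the data shown here, no measured pair shows this step, so the expectation is a step of a 1.9-fold lower number from compound 2 to compound 3 (0.28 log units; within the scatter), leaning toward stronger inhibition but not clearly beyond the scatter. Compound 3 is expected at 1200 nM, between 400 nM and 4000 nM.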

Compound 3, half-maximal inhibitory concentration: 940 nM
Compound 3: middle estimate off by 1.3-fold (0.11 log units), on the high side; the range from low to high includes it.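

In this assay, within the data shown here, chloro in place of methyl on an aromatic carbon gives a 2.4-fold lower number from compound 2 to compound 3 (0.39 log units; beyond the scatter), the first step that can be read at this position, and it points to modestly stronger inhibition. This rests on a single pair. Compound 1 also carries chloro on this ring, but it cannot firm up the trend since its entries spread widely and one of them is a limit of the assay, not a number: the several entries of compound 1 in this assay, 790 nM; > 30000 nM; 380 nM (3 entries)

Going by these compounds, whether bromo, methoxy or an amine at this place would lower the number further stays open. So does whether the step holds when the fluoro group on the same ring is changed.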